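A few compounds are considered here, and "the series" means these few. Any claim that something is new, unique, unknown or untested is made for them only; others in the source may bear on it.

Measured in an ADME assay on 184B5 cells (Homo sapiens) for cytotoxicity, read by sulforhodamine B assay, with a stated time of 48 h; on this read-out lower numbers stand for stronger inhibition of growth and higher numbers for weaker inhibition of growth:
compound 1, `CN(C)CN1C(=O)C(=O)c2c(Br)cccc21`, gives 77900 nM
compound 2, `O=C1C(=O)N(CN2CCCCC2)c2cccc(Br)c21`, gives 85200 nM
compound 3, `Cc1ccc2nc(/N=C3\C(=O)N(CN(C)C)c4cccc(Cl)c43)sc2c1`, gives 5770 nM

Compound 1 and compound 2 share one core. The change between them is piperidin-1-yl in place of dimethylamino on a saturated chain carbon bound to an amide-type nitrogen in a ring, and the step it made in this assay is a 1.1-fold higher number from compound 1 to compound 2 (0.04 log units; within the scatter). Compound 3 carries a different core; the difference between the core of compound 3 and the core of compound 1 is not broken down here. Compound 3 stands at the lowest number of the three, beyond the scatter against compound 1 and against compound 2.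

Compound 4, `Cc1ccc2nc(/N=C3\C(=O)N(CN4CCCCC4)c4cccc(Cl)c43)sc2c1`, is not yet measured in this assay. It differs from compound 3 by piperidin-1-yl in place of dimethylamino on a saturated chain carbon bound to an amide-type nitrogen in a ring. For the measured compounds named here, this is the same change as from compound 1 to compound 2, at the same place, so the pair gives the only guide. The step from compound 3 to compound 4 is expected to be a 1.1-fold higher number from compound 3 to compound 4 (0.05 log units; within the scatter), resting on a 1.1-fold higher number from compound 1 to compound 2 (0.04 log units; within the scatter), which stayed within the scatter. Compound 4 is therefore estimated at 6500 nM, with a range from 3000 nM to 14000 nM.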

Compound 4, concentration for 50% growth inhibition: 82300 nM
Beside the measured number, compound 4's estimate is 13-fold (1.10 log units) below it; the measured number lies above the stated range.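

In this assay, the change from dimethylamino to piperidin-1-yl does not carry over from one core to the other in these two pairs: the same change on two cores in this assay, a 1.1-fold higher number (0.04 log units; within the scatter) from compound 1 to compound 2 and a 14-fold higher number (1.15 log units; beyond the scatter) from compound 3 to compound 4, 13-fold (1.12 log units) apart, beyond the scatter of two such steps. The core of compound 3 gives a 14-fold higher number from compound 3 to compound 4 (1.15 log units; beyond the scatter) on the higher side, so a step within the scatter on the core of compound 1 is no guide to the size of the step on the core of compound 3. This does not show which part of the cores accounts for the gap, since the difference between them is not broken down, and two pairs give no rule for the wider series.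

Open, as far as these compounds go, is whether morpholine or diethylamino on the same saturated chain carbon would follow dimethylamino or piperidin-1-yl on the core of compound 3. Also open, from the compounds shown here alone, is whether bromine in place of the chlorine of compound 3 would alter the size of the step.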